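Aryl amide variation and cytotoxicity in a bis-amide series

The source may hold more compounds than are shown below. What is called first, only, known or untested is meant among the compounds shown, and "the series" means these compounds.

Measured so far:
compound 1 `COc1ccc(C(=O)Nc2ccc3nc(NC(=O)C4CCCCC4)sc3c2)cc1`: 4.9 ug/mL
compound 2 `Cc1ccc(C(=O)Nc2ccc3nc(NC(=O)C4CCCCC4)sc3c2)cc1`: 5.1 ug/mL
compound 3 `O=C(Nc1ccc2nc(NC(=O)C3CCCCC3)sc2c1)c1c(Cl)cccc1Cl`: 0.015 ug/mL

In a functional assay on WI-38 VA13 cells (Homo sapiens) for cytotoxicity (a lower number here means that less compound is needed, a higher number that more compound is needed for the effect), compound 3 holds the lowest number of the three, and both steps toward it are large: a 330-fold lower number from compound 1 to compound 3 (2.51 log units; beyond the scatter) and a 340-fold lower number from compound 2 to compound 3 (2.53 log units; beyond the scatter). The step of a 1.0-fold higher number from compound 1 to compound 2 (0.02 log units; within the scatter) shows that exchanging one para-substituted phenyl for the other left the number essentially unchanged, so the whole effect rests on the 2,6-dichlorophenyl group.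

Compound 4 `Cc1cc(C(=O)Nc2ccc3nc(NC(=O)C4CCCCC4)sc3c2)n(C)n1` has not yet been measured. It differs from compound 3 in one place: 1,3-dimethyl-1H-pyrazol-5-yl in place of 2,6-dichlorophenyl on a carbonyl carbon. Among the compounds with values here, no measured step covers a five-membered ring with two hetero atoms on this carbonyl carbon, so the only bearing steps are those from compound 1 and compound 2 to compound 3, which tell how much was gained by the 2,6-dichlorophenyl group and therefore how much could be lost when it leaves. On that basis compound 4 is expected to move back toward compound 1 and compound 2, a step of a 100-fold higher number from compound 3 to compound 4 (2.00 log units; beyond the scatter), with an estimated value of 1.5 ug/mL in this assay, within a range of 0.15 ug/mL to 12 ug/mL.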

Compound 4, half-maximal effective concentration: 0.12 ug/mL
Compound 4: middle estimate off by 13-fold (1.10 log units), on the high side, and the stated range ends above it.
By their numbers in this assay, from the lowest: compound 3; then compound 4; then compounds 1 and 2 (each within the scatter of the next).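

In this assay, within the data shown here, the 2,6-dichlorophenyl group is not the only group on this carbonyl carbon that gives a low number: 1,3-dimethyl-1H-pyrazol-5-yl brings a 43-fold lower number from compound 2 to compound 4 (1.63 log units; beyond the scatter) and a 41-fold lower number from compound 1 to compound 4 (1.61 log units; beyond the scatter) even though it carries no chlorine. The same exchange measured against the dichlorinated ring gives only an 8.0-fold higher number from compound 3 to compound 4 (0.90 log units; beyond the scatter) so a five-membered aromatic ring with 2 hetero atoms keeps part of the gain seen with compound 3 and the low number does not rest on the 2,6-dichlorophenyl group alone. Nothing at hand accounts for these steps.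

From the compounds shown here alone, it remains open whether a 2,6-dimethylphenyl group or a pyridine ring on this carbonyl carbon would fall with compound 3 or with compounds 1 and 2. Going by these compounds, it is also open how much of the gain with compound 4 depends on the two methyl groups of its pyrazole ring.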